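Compound 3 and its 2-carboxypyrrolidin-1-yl counterpart, compound 4

A few compounds are considered here, and "the series" means these few. Any claim that something is new, unique, unknown or untested is made for them only; others in the source may bear on it.

Measured so far in an ADME assay on Vero cells (Chlorocebus sabaeus) for cytotoxicity, read by MTT assay (on this read-out lower numbers stand for higher toxicity in this test and higher numbers for lower toxicity in this test), are three compounds
- compound 1 `CCn1nc(C(F)(F)F)cc1C(=O)Nc1ccc(S(=O)(=O)N2CCCCC2C)cc1` gives 30000 nM as a single number
- compound 2 `COC(=O)c1ccccc1-n1nc(C(F)(F)F)cc1C(=O)Nc1ccc(S(=O)(=O)N2CCCC2)cc1` gives "not determined" (no result reported) as its entry, with no result reported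
- compound 3 `Cn1nc(C(F)(F)F)cc1C(=O)Nc1ccc(S(=O)(=O)N2CCCCC2)cc1` gives > 300000 nM as a limit of the assay, not a number

Compound 3 therefore has no single number to its name and stands at the limit (the limit of > 300000 nM in this assay, at which 1 of the 3 values shown sits). Only compound 1 supplies a single number, with 30000 nM as its half-maximal cytotoxic concentration.

The next compound is compound 4 `Cn1nc(C(F)(F)F)cc1C(=O)Nc1ccc(S(=O)(=O)N2CCC[C@H]2C(=O)O)cc1`, which carries 2-carboxypyrrolidin-1-yl in place of piperidin-1-yl on a sulfonyl sulfur. For the measured compounds named here, no pair of measured compounds here differs in one place only, so the size of this step can only be expected, not read from a precedent. The expectation starts from compound 3, whose > 300000 nM is a limit and nothing more. The expected result is a number no higher from compound 3 to compound 4 (the limit leaves the size open) and no move beyond the scatter is anticipated. A further report of only a limit would not be a surprise. For compound 4 the estimated value is 300000 nM with an expected range from 100000 nM to 600000 nM in this assay once it is measured.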

Compound 4, half-maximal cytotoxic concentration: > 300000 nM
Compound 4: only a limit was reported (the forecaster's own chance of this, stated with the estimate: 65%); the middle value sits exactly at the limit.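

In this assay compound 4 gives > 300000 nM as a limit and not a number. For the compounds shown here, compound 3 also has only a limit, so no step from compound 3 to compound 4 can be read. The compounds shown leave open how far 2-carboxypyrrolidin-1-yl in place of piperidin-1-yl on a sulfonyl sulfur shifts the half-maximal cytotoxic concentration.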